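Series notes: oxazolidinone side chain swaps and lipophilicity

The source may report more compounds than this note shows. Statements on the series, on what has been measured and on what is new or still open speak of the compounds shown alone.

Three compounds of the series carry a measured value in a physicochemical assay for lipophilicity, read by HPLC, measured as octanol-water partition; on this read-out higher numbers stand for higher lipophilicity and lower numbers for lower lipophilicity. Compound 1 `O=C1O[C@@H](CN2CCC(O)CC2)CN1c1ccc(-n2cc(-c3ccccn3)cn2)c(F)c1` gives 1.63, compound 2 `O=C1CSC(=O)N1C[C@H]1CN(c2ccc(-n3cc(-c4ccccn4)cn3)c(F)c2)C(=O)O1` gives 2.18, and compound 3 `O=C1O[C@@H](CSc2cccs2)CN1c1ccc(-n2cc(-c3ccccn3)cn2)c(F)c1` gives 4.29. Compound 3 stands highest of the three, its nearest neighbour being compound 2 and the furthest compound 1. The steps among them are a number 0.55 log units higher from compound 1 to compound 2 (beyond the scatter), a number 2.66 log units higher from compound 1 to compound 3 (beyond the scatter) and a number 2.11 log units higher from compound 2 to compound 3 (beyond the scatter).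

The next compound, compound 4 `CCNC(=O)NC[C@H]1CN(c2ccc(-n3cc(-c4ccccn4)cn3)c(F)c2)C(=O)O1`, differs from compound 3 as follows: (ethylcarbamoyl)amino in place of (thiophen-2-yl)sulfanyl on a saturated chain carbon bound to a saturated ring carbon. Going by the values given here, the steps that bear on this change are the two that lead into compound 3: the large rise a number 2.66 log units higher from compound 1 to compound 3 (beyond the scatter) and the large rise a number 2.11 log units higher from compound 2 to compound 3 (beyond the scatter). Both show that replacing a group with hydrogen-bond donors or with several acceptors by the (thiophen-2-yl)sulfanyl group raised this assay by a large amount; the reverse replacement by a group with two hydrogen-bond donors is therefore expected to bring a large fall.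

Compound 4 is accordingly expected to show a step of a number 2.49 log units lower from compound 3 to compound 4 (beyond the scatter) in this assay, landing near the readings of compound 1 and compound 2. The estimated value for compound 4 is 1.8, in a range from 1.2 to 2.4.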

Compound 4, partition coefficient: 2.45
The estimate for compound 4 lay 0.65 log units below the measured number; measured number above the stated range.
By their numbers in this assay, from the lowest: compound 1; then compounds 2 and 4 (each within the scatter of the next); then compound 3.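

In this assay, (ethylcarbamoyl)amino in place of (thiophen-2-yl)sulfanyl on a saturated chain carbon bound to a saturated ring carbon gives a number 1.84 log units lower from compound 3 to compound 4 (beyond the scatter), so two groups of 6 heavy atoms each stand far apart at this position, and heavy-atom count alone does not set the reading in this set. Against the other two side chains, the ringless (ethylcarbamoyl)amino group gives a number 0.27 log units higher from compound 2 to compound 4 (within the scatter), which lies within the scatter, and a number 0.82 log units higher from compound 1 to compound 4 (beyond the scatter), which lies beyond it, so compound 4 reads with the 2,4-dioxo-1,3-thiazolidin-3-yl compound and apart from the 4-hydroxypiperidin-1-yl compound. No supporting data are available to account for these differences.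

The step into compound 4 changes the aromatic ring, the sulfur atoms and the hydrogen-bond donors together, so it cannot show which of these changes goes with the fall. An ethylsulfanyl group or a (thiophen-2-yl)amino group at this position would separate these features, and a (propylcarbamoyl)amino group would show how a longer chain on the same unit reads.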